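This account rests on a few compounds, and the source may have more. Where it says the series, first, only, none or still open, it means among the compounds named here.

Compound 1 (`O=C(NCc1ccc(S(=O)(=O)c2cccc(C(F)(F)F)c2)cc1)N1Cc2ccncc2C1`) shows 14 mL/min/kg in an ADME assay on microsomes from liver (Homo sapiens) for pharmacokinetics, read by LC-MS, with a stated time of 60 min, tested at 1 uM (a higher number here means faster removal of the compound, a lower number slower removal), and compound 2 (`O=C(NCc1ccc(S(=O)(=O)c2cncc(C(F)(F)F)c2)cc1)N1Cc2ccncc2C1`) shows 13 mL/min/kg in the same test, while compound 3 (`CCCn1cc(S(=O)(=O)c2ccc(CNC(=O)N3Cc4ccncc4C3)cc2)cn1`) shows 11 mL/min/kg there. Compound 2 therefore stands level with both other compounds within the scatter, and the three numbers do not separate.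

Compound 4 (`O=C(NCc1ccc(S(=O)(=O)C2CCC(F)(F)CC2)cc1)N1Cc2ccncc2C1`) has not been measured. It differs from compound 2 by 4,4-difluorocyclohexyl in place of 5-(trifluoromethyl)pyridin-3-yl on a sulfonyl sulfur.

Three measured steps at that same place bear on this change: (a 1.1-fold lower number from compound 1 to compound 2 (0.03 log units; within the scatter)) and (a 1.3-fold lower number from compound 1 to compound 3 (0.10 log units; within the scatter)) and (a 1.2-fold lower number from compound 2 to compound 3 (0.07 log units; within the scatter)). All three are small and stay within the scatter. None of them, however, brings in a non-aromatic ring of carbon only, so they guide this change only loosely and the range is kept wider than those steps alone would suggest.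

On that evidence, no step beyond the scatter is expected in this assay for this change. The estimated step is (a 1.1-fold higher number from compound 2 to compound 4 (0.03 log units; within the scatter)) and it remains an expectation until measured. For compound 4 the estimate is 14 mL/min/kg (expected range 8 mL/min/kg to 25 mL/min/kg) in the same test.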

Compound 4, clearance: 6 mL/min/kg
For compound 4 the middle estimate is 2.3-fold (0.37 log units) above the measured one, and the stated range ends above it.
By their numbers in this assay, from the lowest: compounds 4, 3, 2 and 1 (each within the scatter of the next, the first and the last beyond it).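

In this assay the place on the sulfonyl sulfur no longer looks silent: the three aromatic groups stayed within the scatter of one another, whereas the non-aromatic ring of carbon only, 4,4-difluorocyclohexyl, gives a 2.2-fold lower number from compound 2 to compound 4 (0.34 log units; beyond the scatter) and a 2.3-fold lower number from compound 1 to compound 4 (0.37 log units; beyond the scatter) in this test. Among the compounds shown here, the separation is modest and incomplete, as the same ring gives a 1.8-fold lower number from compound 3 to compound 4 (0.26 log units; within the scatter) against 1-propyl-1H-pyrazol-4-yl, so compound 4 stands apart from two of the earlier compounds and not from the third. The aromatic groups alone therefore did not show the full response available at this place, and no measured information on these compounds accounts for the step.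

Compound 4 brings in a non-aromatic ring and its two fluorines in a single change, so the contribution of each stays unresolved, and plain cyclohexyl would be the direct comparison for separating them. Also open, as far as these compounds go, is how this place responds to a non-aromatic ring carrying an amine or a carboxylic acid, or to an open alkyl chain on the sulfonyl sulfur.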